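The compounds below may be only part of what the source reports. "The series", "measured", "known", "first", "only" and "open" are said of these compounds alone.

Working notes on the series. The shared core is carried by compound 1 `Nc1nc(N)c(-c2ccc(NCc3ccnc(Cl)c3)cc2)c(COCc2ccccc2)n1`, which in a functional assay on CHOK cells for antagonist activity at growth hormone secretagogue receptor type 1 (Homo sapiens), read by calcium flux (a lower number here means a stronger inhibitor, a higher number a weaker inhibitor), gives 3.6 nM. Compound 2 `N#Cc1ccc(CNc2ccc(-c3c(N)nc(N)nc3COCc3ccccc3)cc2)cc1` gives 19 nM in this assay, and compound 3 `Nc1nc(N)c(-c2ccc(CNc3ccc([N+](=O)[O-])cc3)cc2)c(COCc2ccccc2)n1` gives 16 nM. Among the three numbers compound 3 stands second highest: its gap to compound 2 is within the scatter, a 1.2-fold lower number from compound 2 to compound 3 (0.07 log units; within the scatter), while its gap to compound 1 is beyond it, a 4.4-fold higher number from compound 1 to compound 3 (0.65 log units; beyond the scatter). The remaining measured step, a 5.3-fold higher number from compound 1 to compound 2 (0.72 log units; beyond the scatter), is of similar size. All three steps alter the aryl group or the linker that joins it to the core; none of them touches the substituent on the saturated chain carbon bound to an aromatic carbon.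

Compound 4 `CCc1nc(N)nc(N)c1-c1ccc(CNc2ccc([N+](=O)[O-])cc2)cc1` differs from compound 3 exactly there: methyl in place of benzyloxy on a saturated chain carbon bound to an aromatic carbon. Among the compounds with values here, no measured step bears on this change, so its size cannot be read from the series. The group that leaves carries a six-membered aromatic ring and one hydrogen-bond acceptor, while a single carbon enters; for a change of this extent at an untested position a shift in this assay is expected, more likely toward a higher number, and the step from compound 3 to compound 4 is estimated at a 3.8-fold higher number from compound 3 to compound 4 (0.57 log units; beyond the scatter). Compound 4 is expected at 60 nM, with a range from 10 nM to 400 nM.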

Compound 4, half-maximal inhibitory concentration: 190 nM
Compound 4: the middle estimate sits 3.2-fold (0.50 log units) below what was measured; measured number inside the range.
By their numbers in this assay, from the lowest: compound 1; then compounds 3 and 2 (each within the scatter of the next); then compound 4.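

Within the data shown here, the step at this position, a 12-fold higher number from compound 3 to compound 4 (1.07 log units; beyond the scatter), is the first reading of the substituent on the saturated chain carbon bound to an aromatic carbon, and it is the only step classed as large, the others being modest or within the scatter. It shows that this position is not a silent one in this assay: with the rest of compound 3 held fixed, exchanging benzyloxy for methyl costs more than any change of the aryl group or linker has so far been shown to cost. No measurement available here accounts for the size of this step.

Benzyloxy takes its aromatic ring and its oxygen away together, so the compounds shown do not separate the two: methoxymethyl in place of (benzyloxy)methyl would keep the oxygen without the ring, while a 3-phenylpropyl chain would keep the ring without the oxygen. Also open, on these data alone, is whether a step of this size recurs on the aryl and linker arrangement of compound 1, since the change is read on a single matched pair.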